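Series notes: the step from compound 3 to compound 4

This account rests on a few compounds, and the source may have more. Where it says the series, first, only, none or still open, it means among the compounds named here.

Measured so far, in a functional assay on the whole organism for inhibition, with Rattus norvegicus as the target, read by paw edema, with a stated time of 30 min, at a dose of 40 mg/kg by the oral route; on this read-out higher numbers stand for a stronger effect at the one dose given and lower numbers for a weaker effect:
compound 1 `COc1ccc(OCC2=NCCO2)cc1` gives 33.2%
compound 2 `Clc1ccc(OCC2=NCCO2)cc1` gives 48.2%
compound 3 `Brc1ccccc1OCC1=NCCO1` gives 29.1%

Compound 3 carries the lowest of the three numbers in this assay. Its gap to compound 1 is within the scatter, so the two cannot be ranked against each other; its gap to compound 2 is beyond the scatter, and compound 2 stands clearly higher.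

Among the measured compounds shown here, the one step among measured compounds that differ in a single place is a number 15 percentage points higher from compound 1 to compound 2 (beyond the scatter). It concerns a different exchange and a different place on the ring than the one now in question, so it gives no direct guide; it only shows that a single change of a group on the aromatic carbon can move the read-out by a modest amount in this assay.

Compound 4 `Cc1ccccc1OCC1=NCCO1` differs from compound 3 as follows: methyl in place of bromo on an aromatic carbon. For the measured compounds named here, no measured pair speaks to this exchange, so no step beyond the scatter is assumed in either direction.

The expected result is therefore a number 0.9 percentage points higher from compound 3 to compound 4 (within the scatter), and compound 4 is estimated to give 30% in this assay, with a range of 15% to 45%.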

Compound 4, a percentage reported as inhibition, in the whole organism at one dose (the size of the read-out at that dose, not a potency): 29.5%
Estimate against measurement, compound 4: 0.5 percentage points above, within the range that was stated.
By their numbers in this assay, from the lowest: compounds 3, 4 and 1 (each within the scatter of the next); then compound 2.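

In this assay, methyl in place of bromo on an aromatic carbon, ortho to a group of 7 heavy atoms, gives a number 0.4 percentage points higher from compound 3 to compound 4 (within the scatter); the earlier step concerned a different exchange at a different place on the ring. At this position the two groups therefore cannot be told apart on this read-out at the one dose given, although a bromine atom leaves and a carbon atom enters, and neither group counts a hydrogen-bond donor, a hydrogen-bond acceptor or a net charge. No measured evidence bears on this result.

The compounds shown hold only these two groups at this position, so it remains open whether an amine, a carboxylic acid, a hydroxyl or a longer chain such as propyl at the same place would separate from them beyond the scatter. Going by these compounds, it also remains open whether bromo and methyl would stay indistinguishable at other doses, since a single-dose read-out gives the size of the effect at that dose and not a potency.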